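The compounds below may be only part of what the source reports. "The series", "measured", "known", "first", "only" and "open" are said of these compounds alone.

Compound 1 `COc1cccc([C@H](O)[C@H]2CO[C@H](c3ccc(OC)c(OC)c3)[C@@H](C/C=C/c3ccc(OC)c(OC)c3)C2)c1`: 21200 nM
Compound 2 `COc1cccc(/C=C/C[C@@H]2C[C@@H]([C@@H](O)c3ccc(OC)c(OC)c3)CO[C@H]2c2ccc(OC)c(OC)c2)c1`: 16400 nM
Compound 3 `COc1ccc(/C=C/C[C@H]2C[C@@H]([C@@H](O)c3ccccc3)CO[C@@H]2c2ccccc2)cc1`: 8300 nM

In a functional assay on HeLa cells (Homo sapiens) for cytotoxicity, read by WST assay, with a stated time of 48 h (on this read-out higher numbers stand for weaker inhibition and lower numbers for stronger inhibition), compound 2 gives 16400 nM, the second highest of the three numbers. Compound 1 gives 21200 nM and compound 3 gives 8300 nM, and both of these lie within the scatter of the number for compound 2, so none of the three can be ordered against the others. Compound 4 `COc1ccc(CCC[C@@H]2C[C@@H]([C@@H](O)c3ccc(OC)c(OC)c3)CO[C@H]2c2ccc(OC)c(OC)c2)cc1OC` has not yet been measured. It differs from compound 2 in one place: 2-(3,4-dimethoxyphenyl)ethyl in place of 2-(3-methoxyphenyl)ethenyl on a saturated chain carbon bound to a saturated ring carbon. Among the compounds with values here, no measured pair shows this change, and the three measured values sit within the scatter of one another, so no step beyond the scatter is expected in this assay. Compound 4 is expected to give about 18000 nM, between 7000 nM and 45000 nM. The step of a 1.1-fold higher number from compound 2 to compound 4 (0.04 log units; within the scatter) that this estimate means is expected to stay within the scatter.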

Compound 4, half-maximal inhibitory concentration: 35700 nM
Compound 4: the middle estimate sits 2.0-fold (0.30 log units) below what was measured; low and high end bracket the measured number.
By their numbers in this assay, from the lowest: compounds 3, 2, 1 and 4 (each within the scatter of the next, the first and the last beyond it).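

In this assay, within the data shown here, 2-(3,4-dimethoxyphenyl)ethyl in place of 2-(3-methoxyphenyl)ethenyl gives a 2.2-fold higher number from compound 2 to compound 4 (0.34 log units; beyond the scatter) and so provides the only step here beyond the scatter, a modest one, showing that this position is not indifferent to its substituent. The change removes the chain double bond and alters the methoxy pattern at once, so the step cannot be assigned to either alone. No evidence at hand accounts for it. Still open, going by these compounds, is how a longer chain, or an amine or a carboxylic acid at this position, would read.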